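This account rests on a few compounds, and the source may have more. Where it says the series, first, only, none or still open, it means among the compounds named here.

Measured so far in a functional assay on the whole organism (stomach) with Rattus norvegicus as the target; on this read-out lower numbers stand for an effect already at smaller amounts and higher numbers for an effect only at larger amounts of compound:
Compound 1 `N=C(S)CCN1N=C(c2cccs2)CCC1=O` gives 77.3 mg/kg.
Compound 2 `O=c1cccnn1CCC(=S)N1CCCC1` gives > 100 mg/kg, which is a limit of the assay and not a number.
Compound 3 `COc1ccc(-c2ccc(=O)n(CCC(=N)S)n2)cc1` gives > 100 mg/kg, again a limit of the assay and not a number.

Compound 1 is the only one of the three that returned a number in this assay; the other two sit at the limit of > 100 mg/kg in this assay, at which 2 of the 3 values shown sit. Going by the values given here, no pair of measured compounds differs in a single place, so no measured step is available, and how far compound 1 stands from compounds 2 and 3 is known only as a difference between a number and a limit.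

Compound 4 `CC1=NN(CCC(=N)S)C(=O)CC1` is not yet measured. Against compound 1 it shows methyl in place of thiophen-2-yl on a carbon with a double bond to nitrogen, the shared core otherwise unchanged. Among the compounds with values here, no measured pair tells what this exchange does in this assay, and the three values give no direction to lean on. The expected step of a 1.3-fold higher number from compound 1 to compound 4 (0.11 log units; within the scatter) is set small, toward larger amounts and close to the scatter, with a real chance that compound 4 too returns only a limit. Compound 4 is estimated at 100 mg/kg, in a range from 40 mg/kg to 250 mg/kg.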

Compound 4, dose for half-maximal effect: > 100 mg/kg
Compound 4 was reported as a limit; the forecaster's own chance of this, stated with the estimate: 50%; the middle value sits exactly at the limit.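

The exchange of thiophen-2-yl for methyl, on a carbon with a double bond to nitrogen of the six-membered ring, now has its first measured step in this assay: an at least 1.2-fold higher number from compound 1 to compound 4 (0.11 log units; that floor lies within the scatter). Compound 4 gives > 100 mg/kg, which is a limit of the assay and not a number, so the step is only a floor, and that floor does not establish a real difference between compound 1 and compound 4. What is new is that methyl at this place does not return a number, which leaves compound 1, with thiophen-2-yl, as the only compound in the series that does, while compounds 2, 3 and 4 share one limit: the limit of > 100 mg/kg in this assay, at which 3 of the 4 values shown sit.

From the compounds shown here alone, how large the true step is stays open, since a limit cannot show whether methyl costs much effect or almost none. Also open, going by these compounds, is whether thiophen-2-yl is specifically needed at this place, or whether a group such as furan-2-yl or a longer alkyl chain would also return a number.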